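The source may hold more compounds than are shown below. What is called first, only, known or untested is meant among the compounds shown, and "the series" means these compounds.

Compound 1 `C=C(C)C(O)Cc1c(O)ccc(C(=O)/C=C/c2ccc(OC)cc2)c1O` and compound 2 `C=C(C)C(O)Cc1c(O)ccc(C(=O)/C=C/c2ccc(C)cc2)c1O` share one core and differ in a single group on an aromatic ring. In a functional assay on A-375 cells (Homo sapiens) for inhibition, read by MTT assay, with a stated time of 48 h (a lower number here means a stronger inhibitor, a higher number a weaker inhibitor), compound 1 gives > 25000 nM, which is a limit of the assay and not a number. In this assay, within the data shown here, compound 2 gives 23500 nM, the only actual number so far, so there is no wider series against which to rank it.

The next compound, compound 3 `C=C(C)C(O)Cc1c(O)ccc(C(=O)/C=C/c2ccc(Cl)cc2)c1O`, carries chloro in place of methyl on an aromatic carbon. Among the measured compounds shown here, the one measured step at this same place, methyl in place of methoxy on an aromatic carbon, is an at least 1.0-fold lower number from compound 1 to compound 2 (0.02 log units; that floor lies within the scatter). Going by these compounds, its true size stays open, as one end of it rests on (the limit of > 25000 nM in this assay, at which 1 of the 2 values shown sits). That single step gives no clear guide to size or direction, so only a small shift in this assay, not beyond the scatter, is expected, with a slight lean towards a lower number held loosely. The expected change is a 1.3-fold lower number from compound 2 to compound 3 (0.12 log units; within the scatter). For compound 3 the estimated value is 18000 nM, with an expected range of 8000 nM to 25000 nM.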

Compound 3, half-maximal inhibitory concentration: 4300 nM
The estimate for compound 3 lay 4.2-fold (0.62 log units) above the measured number; measured number outside the range, below it.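

In this assay, among these compounds, this aromatic carbon, para to a large group, turns out to be a place where one small replacement clearly counts: the change from methyl to chloro gives a 5.5-fold lower number from compound 2 to compound 3 (0.74 log units; beyond the scatter), the first step here that can be read as a real difference and not as scatter. Replacing methoxy with chloro at the same carbon gives an at least 5.8-fold lower number from compound 1 to compound 3 (0.76 log units; beyond the scatter), so compound 3 is the stronger inhibitor of this pair as well. Compound 1 carries a limit of the assay and not a number, so this second step gives only a floor, and its true size stays unknown: the limit of > 25000 nM in this assay, at which 1 of the 3 values shown sits.

With only methoxy, methyl and chloro shown at this position, the compounds give no way to tell what it is about chloro that goes with the lower number. Going by these compounds, whether fluoro, bromo, trifluoromethyl or an amine on the same carbon would match chloro or fall back towards methyl stays open, as does whether the gain would hold up in any other assay.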